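This account rests on a few compounds, and the source may have more. Where it says the series, first, only, none or still open, it means among the compounds named here.

Measured so far in a functional assay on RAW264.7 cells (Mus musculus) for inhibition, read by fluorescence, with stated times of 1 h, 24 h and 30 min; on this read-out higher numbers stand for weaker inhibition and lower numbers for stronger inhibition:

Compound 1 `O=C(/C=C/c1ccccc1C(F)(F)F)c1ccc(O)cc1` gives > 10000 nM, a limit of the measurement rather than a number.

Compound 2 `O=C(/C=C/c1ccc(C(F)(F)F)cc1)c1ccccc1` gives > 10000 nM, likewise a limit and not a number.

Compound 3 `O=C(/C=C/c1ccccc1OC(F)(F)F)c1ccc(O)cc1` gives 1340 nM.

Two of the three values sit at the limit of > 10000 nM in this assay, at which 2 of the 3 values shown sit, so only compound 3 carries a number in this assay. Within the data shown here, the one counted step is an at least 7.4-fold lower number from compound 1 to compound 3 (0.87 log units; beyond the scatter), brought about by trifluoromethoxy in place of trifluoromethyl on an aromatic carbon. The starting point of that step is a limit. The true size of the step is therefore not known, only its floor.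

Compound 4 `O=C(/C=C/c1ccc(OC(F)(F)F)cc1)c1ccccc1` has not yet been measured in this assay. It differs from compound 2 by trifluoromethoxy in place of trifluoromethyl on an aromatic carbon. Among the measured compounds shown here, this is the same kind of change as the one from compound 1 to compound 3, but not the same: there the group sits ortho to a large group, here it sits para to a large group. How compound 2 itself differs from compound 1 is not broken down here; the two cores are taken as given.

What to expect for compound 4 rests on a single measured step, set on a different core and at a different place. The step from compound 2 to compound 4 is expected to be an at least 3.3-fold lower number from compound 2 to compound 4 (0.52 log units; beyond the scatter), in line with an at least 7.4-fold lower number from compound 1 to compound 3 (0.87 log units; beyond the scatter), with wide uncertainty since compound 2 sits at a limit. Compound 4 is therefore estimated at 3000 nM, with a range of 800 nM to 10000 nM.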

Compound 4, half-maximal inhibitory concentration: > 10000 nM
Compound 4: only a limit was reported (the forecaster's own chance of this, stated with the estimate: 40%); at least 3.3-fold (0.52 log units) between middle value and limit.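

Compound 2 and compound 4 both sit at a limit in this assay, so no step can be read for trifluoromethoxy in place of trifluoromethyl between them: the limit of > 10000 nM in this assay, at which 3 of the 4 values shown sit.

The compounds shown leave open whether this change lowers the number at all on the core of compound 2, and how far apart compound 2 and compound 4 truly lie.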